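The compounds below may be only part of what the source reports. "The series", "measured", "known", "first", "only" and "open" are said of these compounds alone.

The measured compounds in a functional assay on ileum for inhibition of histamine H1 receptor (Cavia porcellus); on this read-out lower numbers stand for stronger inhibition and higher numbers for weaker inhibition:
Compound 1 `CN1CCN(c2nc3ccccc3[nH]2)CC1` gives > 3000 nM, which is a limit of the assay and not a number.
Compound 2 `COCCCn1c(N2CCN(C)CC2)nc2ccccc21` gives 860 nM.
Compound 3 `CN1CCN(c2nc3ccccc3n2-c2ccccc2)CC1` gives 760 nM.

Among the numbers shown, compound 2 stands highest, but its only neighbour with a number, compound 3, sits within the scatter of it (a 1.1-fold lower number from compound 2 to compound 3 (0.05 log units; within the scatter)). Compound 4 `CN1CCN(c2nc3ccccc3n2CCOc2ccccc2)CC1` differs from compound 2 by phenoxy in place of methoxymethyl on a saturated chain carbon, two bonds along the chain from an aromatic nitrogen. Going by the values given here, the steps that bear on this change are an at least 3.4-fold lower number from compound 1 to compound 2 (0.54 log units; beyond the scatter) and an at least 3.9-fold lower number from compound 1 to compound 3 (0.59 log units; beyond the scatter), both read from the limit (the limit of > 3000 nM in this assay, at which 1 of the 3 values shown sits), together with a 1.1-fold lower number from compound 2 to compound 3 (0.05 log units; within the scatter), where a phenyl in place of a 3-methoxypropyl moved the number by nothing beyond the scatter. An aromatic ring placed further out on the same chain is therefore expected to give at most a small step for compound 4, a 1.4-fold lower number from compound 2 to compound 4 (0.16 log units; within the scatter). For compound 4 the estimate is 600 nM, expected to lie between 250 nM and 1500 nM.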

Compound 4, half-maximal inhibitory concentration: 6.9 nM
Beside the measured number, compound 4's estimate is 87-fold (1.94 log units) above it, outside the stated range (below it).
By their numbers in this assay, from the lowest: compound 4; then compounds 3 and 2 (each within the scatter of the next). At a limit, above all of these: compound 1.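

Phenoxy in place of methoxymethyl on a saturated chain carbon, two bonds along the chain from an aromatic nitrogen, gives a 120-fold lower number from compound 2 to compound 4 (2.10 log units; beyond the scatter) in this assay. The earlier compounds shown here showed no such response: phenyl in place of 3-methoxypropyl on the aromatic nitrogen gave a 1.1-fold lower number from compound 2 to compound 3 (0.05 log units; within the scatter). An aromatic ring set directly on that nitrogen and a phenoxy carried on the chain are therefore not interchangeable here.

Going by these compounds, whether a plain phenyl on the chain, a longer chain or an amine at this carbon would keep the number this low stays open. Nothing shown gives a cause for the step.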